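This account rests on a few compounds, and the source may have more. Where it says the series, first, only, none or still open, it means among the compounds named here.

Measured compounds in an in vitro functional assay on 1321-N1 cells for agonist activity at P2Y purinoceptor 6 (Homo sapiens), read by scintillation proximity assay and inositol phosphate accumulation; on this read-out lower numbers stand for an effect already at smaller amounts and higher numbers for an effect only at larger amounts of compound:

Compound 1 `CCSc1nc(=O)ccn1[C@@H]1O[C@H](COP(=O)(O)O)[C@@H](O)[C@H]1O`: reported only as a limit of the assay, > 100000 nM.
Compound 2 `CNc1nc(=O)ccn1[C@@H]1O[C@H](COP(=O)(O)O)[C@@H](O)[C@H]1O`: reported only as a limit of the assay, > 100000 nM.
Compound 3 `Nc1nc(=O)ccn1[C@@H]1O[C@H](COP(=O)(O)O)[C@@H](O)[C@H]1O`: reported only as a limit of the assay, > 100000 nM.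

Compound 3 therefore stands nowhere in particular on this read-out: its value is a limit and not a number, and the same holds for the other two compounds, all of them sitting at the limit of > 100000 nM in this assay, at which 3 of the 3 values shown sit. The steps among them are accordingly unreadable: a step that the two limits leave unreadable from compound 1 to compound 2, a step that the two limits leave unreadable from compound 1 to compound 3 and a step that the two limits leave unreadable from compound 2 to compound 3 each have a size the two limits hide.

Compound 4 `O=c1ccn([C@@H]2O[C@H](COP(=O)(O)O)[C@@H](O)[C@H]2O)c(SCCc2ccccc2)n1` differs from compound 3 by phenethylsulfanyl in place of amino on an aromatic carbon. Among the measured compounds shown here, only the steps from compound 1, which carries an ethylsulfanyl group, bear on a sulfanyl substituent at this place, and both of those are unreadable; no measured step gives a direction or a size for replacing the amino group by a larger sulfanyl chain. The expectation for compound 4 rests on the limit shown by compound 3, > 100000 nM, so the step is estimated as a number no higher from compound 3 to compound 4 (the limit leaves the size open), that is, no readable change. Compound 4 is thus expected to give about 100000 nM in this assay, within a range from 20000 nM to 300000 nM, most likely again as a limit.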

Compound 4, half-maximal effective concentration: > 100000 nM
Compound 4 ended at the assay's limit; the forecaster's own chance of this, stated with the estimate: 70%; the middle value sits exactly at the limit.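

In this assay compound 4 gives > 100000 nM, which is a limit and not a number. The steps to compound 4 from compound 1, compound 2 and compound 3 therefore cannot be read, and the four compounds stand together: the limit of > 100000 nM in this assay, at which 4 of the 4 values shown sit.

The compounds shown leave open whether any group at this place on the shared core gives a measurable value in this assay.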